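The compounds below may be only part of what the source reports. "The series", "measured", "known", "first", "only" and "open" are said of these compounds alone.

Series notes. Compound 1 `CC1=CC[C@H](C(C)(C)NC(=S)N/N=C/c2ccccc2Cl)CC1` and compound 2 `CC1=CC[C@H](C(C)(C)NC(=S)N/N=C/c2cccc(Cl)c2)CC1` share the same atoms joined differently: the difference between their cores is 3-chlorophenyl in place of 2-chlorophenyl on a carbon with a double bond to nitrogen. In a functional assay on NCI/ADR-RES cells (Homo sapiens) for inhibition, read by sulforhodamine B assay, with a stated time of 48 h (on this read-out higher numbers stand for weaker inhibition of growth and lower numbers for stronger inhibition of growth), compound 1 gives 75000 nM and compound 2 gives 67500 nM; the step of a 1.1-fold lower number from compound 1 to compound 2 (0.05 log units; within the scatter) is within the scatter. Compound 3 `CC1=CC[C@H](C(C)(C)NC(=S)N/N=C/c2ccccc2[N+](=O)[O-])CC1` carries the change nitro in place of chloro on an aromatic carbon relative to compound 1, and in this assay compound 3 gives 19200 nM, a step of a 3.9-fold lower number from compound 1 to compound 3 (0.59 log units; beyond the scatter).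

Compound 4 `CC1=CC[C@H](C(C)(C)NC(=S)N/N=C/c2cccc([N+](=O)[O-])c2)CC1` is not yet measured. It differs from compound 2 by nitro in place of chloro on an aromatic carbon, the same kind of change, though here the place is meta to a large group rather than ortho to a large group. Because the earlier step of a 3.9-fold lower number from compound 1 to compound 3 (0.59 log units; beyond the scatter) was modest but beyond the scatter, a step of a 3.4-fold lower number from compound 2 to compound 4 (0.53 log units; beyond the scatter) is expected from compound 2 to compound 4 in this assay. The estimate for compound 4 in this assay is 20000 nM, expected to lie between 8000 nM and 50000 nM.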

Compound 4, concentration for 50% growth inhibition: > 100000 nM
Compound 4: a limit, no number; the forecaster's own chance of this, stated with the estimate: 5%; at least 5.0-fold (0.69 log units) between middle value and limit.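

Compound 4 gives > 100000 nM in this assay, which is a limit of the assay and not a number. Read as a floor, the new step is an at least 1.4-fold higher number from compound 2 to compound 4 (0.17 log units; that floor lies within the scatter), and nitro in place of chloro does not carry over as a constant step from one core to the other: the same change on two cores in this assay, a 3.9-fold lower number (0.59 log units; beyond the scatter) from compound 1 to compound 3 and an at least 1.4-fold higher number (0.17 log units; that floor lies within the scatter) from compound 2 to compound 4, at least 5.7-fold (0.76 log units) apart, beyond the scatter of two such steps

From the compounds shown here alone, the true size of this step stays unknown, with only its floor given, and two pairs cannot show whether the place on the aromatic ring or something else separates the outcomes. The compounds shown leave open whether other groups on the aromatic ring also give different steps on the two cores. An amine or a nitrile at both places would be a direct test.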